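This account rests on a few compounds, and the source may have more. Where it says the series, first, only, none or still open, it means among the compounds named here.

Working notes on the series, all read in a toxicity assay on J774.A1 cells (Mus musculus) for cytotoxicity, read by SYBR Green assay, with a stated time of 1 h; a higher number here means that more compound is needed for the effect, a lower number that less compound is needed. Compound 1 (`CN(C)c1ccc2cc(-c3cn(C)c4ccccc34)c(N)nc2c1`) gives 3700 nM. Compound 3 (`CNc1ccc2cc(-c3cc(Cl)cc(Cl)c3)c(N)nc2c1`) gives 3700 nM, level with compound 1 at the digits shown. Compound 2 (`CN(C)c1ccc2cc(-c3nc4ccccc4s3)c(N)nc2c1`) gives 4900 nM, which is still within the scatter of compound 1. Compound 1 therefore stands in a tight group of three values, with no real separation among them.

The next compound to be read is compound 4 (`Cn1cc(-c2cc3ccc(N4CCCCC4)cc3nc2N)c2ccccc21`). It keeps the core of compound 1 but carries piperidin-1-yl in place of dimethylamino on an aromatic carbon. For the measured compounds named here, no measured pair differs in one place only, so this change has no direct precedent. Going by the values given here, the only guide is the closeness of the three values, despite their differing structures. On that basis, no step beyond the scatter is expected in this assay, and no firm direction can be assigned. The estimated step of a 1.1-fold lower number from compound 1 to compound 4 (0.02 log units; within the scatter) is expected to stay within the scatter. For compound 4 the estimate is 3500 nM, with an expected range of 1500 nM to 8000 nM.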

Compound 4, half-maximal effective concentration: 560 nM
The estimate for compound 4 lay 6.3-fold (0.80 log units) above the measured number; the measured number lies below the stated range.
By their numbers in this assay, from the lowest: compound 4; then compounds 1, 3 and 2 (each within the scatter of the next).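

Piperidin-1-yl in place of dimethylamino on an aromatic carbon gives a 6.6-fold lower number from compound 1 to compound 4 (0.82 log units; beyond the scatter) in this assay, the first reading of a change in one place only. For the compounds shown here, this position is therefore not indifferent to the group it carries, which the earlier compounds could not show, since no pair among them differed in one place only and their values stayed within the scatter of one another. No measurement at hand speaks to the cause of this step.

Still open, going by these compounds, is whether the step belongs to the ring as such or to the larger group, which pyrrolidin-1-yl, morpholin-4-yl or an open diethylamino group at this place would help separate. Also open, on these data alone, is whether the same change would carry over to compound 2 , which bears dimethylamino too.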